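From methoxy to cyano: what compound 4 may show

The source may report more compounds than this note shows. Statements on the series, on what has been measured and on what is new or still open speak of the compounds shown alone.

In a functional assay on MC-38 cells (Mus musculus) for antiproliferative activity (a lower number here means a stronger inhibitor, a higher number a weaker inhibitor), compound 3 (`COc1ccc(S(=O)(=O)Nc2cccc3c(Cl)c[nH]c23)cc1`) gives 0.2 ug/mL as its value. That lies within the usual scatter of compound 2 (`N#Cc1ccc(S(=O)(=O)Nc2cccc3c(C#N)c[nH]c23)cc1`) at 0.12 ug/mL and is clearly lower than compound 1 (`N#Cc1ccc(S(=O)(=O)Nc2cccc3cc[nH]c23)cc1`) at 1.8 ug/mL on the same scale.

Compound 4 (`N#Cc1ccc(S(=O)(=O)Nc2cccc3c(Cl)c[nH]c23)cc1`) differs from compound 3 by having cyano in place of methoxy on an aromatic carbon, para to a large group (cyano in place of methoxy on an aromatic carbon). Going by the values given here, the only measured step is a 15-fold lower number from compound 1 to compound 2 (1.18 log units; beyond the scatter) and it is large, but it puts cyano in place of hydrogen, not methoxy, so this swap has no direct measurement. Compound 2 already carries the entering cyano and reads 0.12 ug/mL in this assay as its value, close to compound 3. Compound 1 carries it too, so the group alone does not set the number.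

No step beyond the scatter is therefore expected in this assay for this swap. The estimated change is a 1.3-fold lower number from compound 3 to compound 4 (0.12 log units; within the scatter) and no more than that. For compound 4 the estimate is 0.15 ug/mL with an expected range from 0.05 ug/mL to 0.5 ug/mL in this assay.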

Compound 4, half-maximal inhibitory concentration: 0.13 ug/mL
Beside the measured number, compound 4's estimate is 1.2-fold (0.06 log units) above it; the measured number falls inside the stated range.
By their numbers in this assay, from the lowest: compounds 2, 4 and 3 (each within the scatter of the next); then compound 1.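

In this assay, cyano in place of methoxy on an aromatic carbon, para to a large group, gives a 1.5-fold lower number from compound 3 to compound 4 (0.19 log units; within the scatter), so with chloro held in place these two groups cannot be told apart at this position. At the other site, chloro in place of hydrogen gives a 14-fold lower number from compound 1 to compound 4 (1.14 log units; beyond the scatter), and chloro in place of cyano gives a 1.1-fold higher number from compound 2 to compound 4 (0.03 log units; within the scatter), so the large step away from hydrogen is not unique to cyano. Nothing available explains why these groups give such similar numbers.

The compounds shown leave open whether an amine or a carboxylic acid at the cyano and methoxy position would keep the number this low. They also leave open whether a methyl or a bromo group could stand in for chloro at the other site.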